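From methoxy to (1-(tert-butyl)azetidin-3-yl)oxy

This account rests on a few compounds, and the source may have more. Where it says the series, first, only, none or still open, it means among the compounds named here.

Measured in a functional assay on A549 cells (Homo sapiens) for antiproliferative activity, read by MTT assay, with a stated time of 48 h; on this read-out higher numbers stand for weaker inhibition and lower numbers for stronger inhibition:
Compound 1 `CCOc1cc(-c2ccc3[nH]ccc3c2)cn2c(-c3cc(OC)c(OC)c(OC)c3)nnc12`: 589 nM
Compound 2 `COc1cc(-c2nnc3c(OC)cc(-c4ccc5[nH]ccc5c4)cn23)cc(OC)c1OC`: 167 nM
Compound 3 `COc1cc(-c2nnc3c(OC4CCC4)cc(-c4ccc5[nH]ccc5c4)cn23)cc(OC)c1OC`: 232 nM
Compound 4 `COc1cc(-c2nnc3c(OC4CN(C(C)(C)C)C4)cc(-c4ccc5[nH]ccc5c4)cn23)cc(OC)c1OC`: not yet measured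

Compound 2 stands at the low end of these numbers, the end of stronger inhibition, but it is not separated from compound 3. The data show a 1.4-fold higher number from compound 2 to compound 3 (0.14 log units; within the scatter).

Compound 4 differs from compound 2 as follows: 1-(tert-butyl)azetidin-3-yl in place of methyl on an oxygen on an aromatic ring.

All measured steps alter the group on this same oxygen. Replacing methyl with cyclobutyl gave a 1.4-fold higher number from compound 2 to compound 3 (0.14 log units; within the scatter), so a larger group need not bring a large step. Compound 1 goes against any simple trend with size, as the data show a 3.5-fold lower number from compound 1 to compound 2 (0.55 log units; beyond the scatter) and a 2.5-fold lower number from compound 1 to compound 3 (0.40 log units; beyond the scatter). Among the compounds with values here, no measured compound carries a nitrogen in this group, so the range stays wide.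

A small rise is expected, a 1.8-fold higher number from compound 2 to compound 4 (0.25 log units; within the scatter). For compound 4 the estimated value is 300 nM, with an expected range of 100 nM to 900 nM.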

Compound 4, half-maximal inhibitory concentration: > 10000 nM
Compound 4 was reported as a limit (the forecaster's own chance of this, stated with the estimate: 2%); at least 33-fold (1.52 log units) between middle value and limit.
By their numbers in this assay, from the lowest: compounds 2 and 3 (each within the scatter of the next); then compound 1. At a limit, above all of these: compound 4.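

The earlier steps shown here on this oxygen were small or modest, with methyl and cyclobutyl within the scatter of each other, but that does not hold for every group here. With 1-(tert-butyl)azetidin-3-yl on the oxygen, the data show an at least 59-fold higher number from compound 2 to compound 4 (1.77 log units; beyond the scatter) and an at least 43-fold higher number from compound 3 to compound 4 (1.63 log units; beyond the scatter) and also an at least 16-fold higher number from compound 1 to compound 4 (1.22 log units; beyond the scatter) for the ethyl compound. Compound 4 is reported only as a limit: the limit of > 10000 nM in this assay, at which 1 of the 4 values shown sits.

The compounds shown do not separate the ring nitrogen from the tert-butyl group. An unsubstituted azetidin-3-yl or a dimethylaminoethyl chain on this oxygen would bear on that question.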